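The source may hold more compounds than are shown below. What is called first, only, known or untested is meant among the compounds shown, and "the series" means these compounds.

In a functional assay on HeLa cells (Homo sapiens) for antiproliferative activity, with a stated time of 48 h (on this read-out lower numbers stand for stronger inhibition and higher numbers for weaker inhibition), compound 1 (`C=C(Br)C(=O)Nc1ccc(/C=C/C(=O)c2ccc(Br)cc2)cc1`) gives 1000 nM, and compound 2 (`C=C(Br)C(=O)Nc1ccc(/C=C/C(=O)c2ccc(I)cc2)cc1`) gives 7700 nM, the higher of the two numbers. Compound 3 (`C=C(Br)C(=O)Nc1ccc(/C=C/C(=O)c2ccc(OCC)cc2)cc1`) has not yet been measured. It carries ethoxy in place of iodo on an aromatic carbon. Among the compounds with values here, only one measured step bears on this change, a 7.7-fold higher number from compound 1 to compound 2 (0.89 log units; beyond the scatter), a modest step beyond the scatter for iodo in place of bromo at the same place. Within the data shown here, it shows that a swap there can move the number, but no ethoxy compound has been measured, and the direction remains uncertain. With compound 2 at the top of the pair at 7700 nM, a modest move towards a lower number in this assay is expected. The estimated step is a 2.6-fold lower number from compound 2 to compound 3 (0.41 log units; beyond the scatter). For compound 3 the expected value is 3000 nM, within an estimated range from 800 nM to 10000 nM.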

Compound 3, half-maximal inhibitory concentration: 750 nM
The estimate for compound 3 lay 4.0-fold (0.60 log units) above the measured number, outside the stated range (below it).
By their numbers in this assay, from the lowest: compounds 3 and 1 (each within the scatter of the next); then compound 2.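

In this assay, ethoxy in place of iodo gives a 10-fold lower number from compound 2 to compound 3 (1.01 log units; beyond the scatter), showing that this place, on an aromatic carbon para to a large group, does not need a halogen to reach the lower numbers seen so far. Ethoxy in place of bromo gives a 1.3-fold lower number from compound 1 to compound 3 (0.12 log units; within the scatter), so compound 1 and compound 3 cannot be told apart here, and among the three groups only iodo, in compound 2, stands apart. Nothing measured on these compounds offers a cause for these steps.

As far as these compounds go, it remains open whether a methoxy group, a longer alkoxy chain, an amine or a carboxylic acid at this place would match ethoxy and bromo or give a number closer to that of iodo. Also open, from the compounds shown here alone, is whether these steps would hold if the rest of the shared core changed.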